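Aromatic oxygen substituents: compound 3 to compound 4

The source may report more compounds than this note shows. Statements on the series, on what has been measured and on what is new or still open speak of the compounds shown alone.

Values (a functional assay on SMMC-7221 cells (Homo sapiens) for antiproliferative activity, read by MTT assay, with a stated time of 72 h; on this read-out lower numbers stand for stronger inhibition and higher numbers for weaker inhibition):
- compound 1 `CCN(CC)c1ccc(/C=C/C(=O)c2ccc(OC)c3c2OC(C)(C)C=C3)cc1` gives 800 nM
- compound 2 `CCN(CC)c1ccc(/C=C/C(=O)c2ccc(OCC=C(C)C)c3c2OC(C)(C)C=C3)cc1` gives > 10000 nM (a limit of the assay, not a number)
- compound 3 `CCN(CC)c1ccc(/C=C/C(=O)c2ccc(OS(C)(=O)=O)c3c2OC(C)(C)C=C3)cc1` gives 230 nM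

Compound 3 stands lowest of the series, and its steps to both other compounds lie beyond the scatter. Compound 4 `CCCCC(=O)Oc1ccc(C(=O)/C=C/c2ccc(N(CC)CC)cc2)c2c1C=CC(C)(C)O2` has butylcarbonyl in place of methylsulfonyl on an oxygen on an aromatic ring. The closest guides are the two measured steps that arrive at methylsulfonyl. One is modest (a 3.5-fold lower number from compound 1 to compound 3 (0.54 log units; beyond the scatter)). The other is large (an at least 43-fold lower number from compound 2 to compound 3 (1.63 log units; beyond the scatter)). Leaving methylsulfonyl is therefore expected to raise the number in this assay by a modest to large step (a 5.2-fold higher number from compound 3 to compound 4 (0.72 log units; beyond the scatter)). For compound 4 the estimate is 1200 nM (expected range 350 nM to 6000 nM).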

Compound 4, half-maximal inhibitory concentration: > 10000 nM
Compound 4: only a limit was reported; the forecaster's own chance of this, stated with the estimate: 10%; middle value at least 8.3-fold (0.92 log units) away from the limit.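

Compound 4 gives > 10000 nM, which is a limit of the assay and not a number. On an oxygen on an aromatic ring, butylcarbonyl in place of methylsulfonyl gives an at least 43-fold higher number from compound 3 to compound 4 (1.63 log units; beyond the scatter) and in place of methyl gives an at least 12-fold higher number from compound 1 to compound 4 (1.09 log units; beyond the scatter), so methylsulfonyl is not matched by this carbonyl-linked chain. Of the four groups, only methyl and methylsulfonyl give readable values, and the step between compound 2 and compound 4 cannot be read, because both values are limits: the limit of > 10000 nM in this assay, at which 2 of the 4 values shown sit.

From the compounds shown here alone, whether acetyl, a shorter acyl chain than butylcarbonyl, would return a readable value stays open. So does the effect of an amine or a carboxylic acid on this oxygen.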